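Replacing 4-carboxyphenyl in compound 1: working notes

The compounds below may be only part of what the source reports. "The series", "measured", "known", "first", "only" and "open" are said of these compounds alone.

Measured in a functional assay on DU-145 cells (Homo sapiens) for inhibition, read by trypan blue exclusion, with a stated time of 96 h; on this read-out higher numbers stand for weaker inhibition of growth and lower numbers for stronger inhibition of growth:
- compound 1 `O=C(O)c1ccc(C(=O)/C(=C\c2ccc([N+](=O)[O-])c(O)c2)SCc2ccc(Br)cc2)cc1`: 10000 nM
- compound 2 `O=C(O)c1ccc(C(=O)/C(=C\c2ccc(Cl)c([N+](=O)[O-])c2)SCc2ccc(Br)cc2)cc1`: 500 nM

Among the measured compounds shown here, of the two numbers so far, the higher belongs to compound 1 at 10000 nM. The next entry is compound 3 `O=C(/C(=C\c1ccc([N+](=O)[O-])c(O)c1)SCc1ccc(Br)cc1)c1cc(Cl)ccc1O`, not yet measured in this assay. It differs from compound 1 as follows: 5-chloro-2-hydroxyphenyl in place of 4-carboxyphenyl on a carbonyl carbon. In words, this is 5-chloro-2-hydroxyphenyl in place of 4-carboxyphenyl on a carbonyl carbon, with the 3-hydroxy-4-nitrophenyl group kept.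

For the measured compounds named here, the only measured step is large: a 20-fold lower number from compound 1 to compound 2 (1.30 log units; beyond the scatter). It concerns the other aryl group, so it shows how far one change can move the numbers here, not what this change will do. Going by the values given here, no measured pair tests a change on the carbonyl carbon. A lower number is expected, though on weak grounds, since compound 1 at 10000 nM sits at the top of the measured values. The expected change should be smaller than a 20-fold lower number from compound 1 to compound 2 (1.30 log units; beyond the scatter), and a wide range is kept. The expected size is a 3.3-fold lower number from compound 1 to compound 3 (0.52 log units; beyond the scatter). The estimate for compound 3 is 3000 nM, with an expected range of 600 nM to 12000 nM.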

Compound 3, concentration for 50% growth inhibition: 10000 nM
For compound 3 the middle estimate is 3.3-fold (0.52 log units) below the measured one; the measured number falls inside the stated range.
By their numbers in this assay, from the lowest: compound 2; then compounds 1 and 3 (each within the scatter of the next).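

In this assay, among the compounds shown here, the exchange of 4-carboxyphenyl for 5-chloro-2-hydroxyphenyl on a carbonyl carbon gives no change at the digits printed from compound 1 to compound 3 (within the scatter) and forms the first measured pair at this position. With the 3-hydroxy-4-nitrophenyl group kept, this single pair shows two quite different aryl groups on the carbonyl carbon giving the same number, whereas the change on the other aryl group gave a 20-fold lower number from compound 1 to compound 2 (1.30 log units; beyond the scatter) in the same series. No supporting data bear on this result, so it stands as an observation without an explanation.

Going by these compounds, both compounds of the new pair carry the 3-hydroxy-4-nitrophenyl group, so it remains open whether 5-chloro-2-hydroxyphenyl would leave the number unmoved alongside the 4-chloro-3-nitrophenyl group, where compound 2 gives 500 nM in this assay. Also open, on these data alone, is what an aryl group bearing an amine, or a longer chain ending in a carboxylic acid, would do on the carbonyl carbon, as two aryl groups in one background cannot show how far this position accepts change.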